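Cytotoxicity notes on a quinoline series with silyl side chain

A few compounds are considered here, and "the series" means these few. Any claim that something is new, unique, unknown or untested is made for them only; others in the source may bear on it.

Of the compounds shown here, three have been measured in an ADME assay on HepG2 2.2.15 cells (Homo sapiens) for cytotoxicity; on this read-out higher numbers stand for lower toxicity in this test and lower numbers for higher toxicity in this test. Compound 1 `ClCCc1c(Cl)nc2ccc(Cl)cc2c1-c1ccccc1Cl` reaches only a limit of the assay, > 1400000 nM. Compound 2 `COc1nc2ccc(Cl)cc2c(-c2ccccc2Cl)c1CCO` gives a number, 141000 nM. Compound 3 `CC(C)(C)[Si](CCc1c(OCc2c(Cl)cccc2Cl)nc2ccc(Cl)cc2c1-c1ccccc1Cl)(c1ccccc1)c1ccccc1` also reaches only a limit, > 1020000 nM. Among the measured compounds shown here, compound 3 therefore stands at one of the two limits seen here, (the limit of > 1020000 nM in this assay, at which 1 of the 3 values shown sits), while compound 1 sits at the other, (the limit of > 1400000 nM in this assay, at which 1 of the 3 values shown sits); no step between the measured compounds can be computed, as each pair differs in more than one place.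

Compound 4 `CC(C)(C)[Si](CCc1c(Nn2nnc3ccccc32)nc2ccc(Cl)cc2c1-c1ccccc1Cl)(c1ccccc1)c1ccccc1` differs from compound 3 by a group of 10 heavy atoms (6 carbon, 4 nitrogen; one five-membered aromatic ring with 3 hetero atoms, one six-membered aromatic ring of carbon only) in place of a group of 10 heavy atoms (7 carbon, 1 oxygen, 2 chlorine; one six-membered aromatic ring of carbon only), on an aromatic carbon. The new group carries a hydrogen-bond donor that the old one lacks, with the same count of heavy atoms. For the measured compounds named here, no measured step in this assay informs this change, so the expectation is a step of small size from compound 3 to compound 4, an at least 1.2-fold lower number from compound 3 to compound 4 (0.10 log units; that floor lies within the scatter), with a good chance that this assay again reports only a limit. For compound 4 the expected value in this assay is 800000 nM, in the range 200000 nM to 3000000 nM.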

Compound 4, half-maximal cytotoxic concentration: > 1250000 nM
Compound 4 gave a limit, no number; the forecaster's own chance of this, stated with the estimate: 60%; middle value at least 1.5-fold (0.19 log units) away from the limit.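

In this assay, among the compounds shown here, compound 3 and compound 4 both reach only limits, not numbers, so no step between them can be read. The compounds shown leave open whether replacing the (2,6-dichlorobenzyl)oxy group of compound 3 with the group of compound 4 changes this read-out at all.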